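The compounds below may be only part of what the source reports. "The series", "measured", "known", "first", "only" and "open" are said of these compounds alone.

Measured so far in a functional assay on the whole organism for antagonist activity, with Rattus norvegicus as the target; a higher number here means that more compound is needed for the effect, a lower number that less compound is needed:
compound 1 `c1ccc2c(c1)CCC2CCN1CCN(c2cccc3c2OCCO3)CC1` gives 1.29 mg/kg
compound 2 `c1ccc2c(c1)CCC2CCCN1CCN(c2cccc3c2OCCO3)CC1` gives 0.29 mg/kg
compound 3 `c1ccc2c(c1)CC(CCN1CCN(c3cccc4c3OCCO4)CC1)C2` gives 0.27 mg/kg

Within the data shown here, the one change that recurs is 2,3-dihydro-1H-inden-2-yl in place of 2,3-dihydro-1H-inden-1-yl on a saturated chain carbon, two bonds along the chain from an amine nitrogen in a ring; measured once, it gives a 4.8-fold lower number from compound 1 to compound 3 (0.68 log units; beyond the scatter). Compound 2 and compound 3 lie within the scatter of each other, so nothing orders them; compound 1 stands apart from both. The difference between the cores of compound 1 and compound 2 is not broken down here.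

Compound 4 `c1ccc2c(c1)CC(CCCN1CCN(c3cccc4c3OCCO4)CC1)C2` remains to be measured in this assay. It differs from compound 2 by 2,3-dihydro-1H-inden-2-yl in place of 2,3-dihydro-1H-inden-1-yl on a saturated chain carbon, three bonds along the chain from an amine nitrogen in a ring. Among the measured compounds shown here, this is the same kind of change as the one from compound 1 to compound 3, not the same: there the place was two bonds along the chain from an amine nitrogen in a ring, here it is three bonds along the chain. Beside a 4.8-fold lower number from compound 1 to compound 3 (0.68 log units; beyond the scatter), the step expected here is a 2.4-fold lower number from compound 2 to compound 4 (0.38 log units; beyond the scatter), smaller, because compound 2 already sits at 0.29 mg/kg while the earlier step began from a higher number, and the single precedent at a shifted place is taken with caution. For compound 4 the expected value is 0.12 mg/kg, with an estimated range from 0.04 mg/kg to 0.4 mg/kg.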

Compound 4, dose for 50% inhibition: 0.47 mg/kg
Compound 4: the middle estimate sits 3.9-fold (0.59 log units) below what was measured, outside the stated range (above it).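

In this assay, placing 2,3-dihydro-1H-inden-2-yl where 2,3-dihydro-1H-inden-1-yl stood, on a saturated chain carbon three bonds along the chain from an amine nitrogen in a ring, gives a 1.6-fold higher number from compound 2 to compound 4 (0.21 log units; within the scatter), so no real shift can be read at this place. The gain seen on the shorter chain therefore does not carry over to the core of compound 2, and the two steps differ by more than scatter alone would allow: the same change on two cores in this assay, a 4.8-fold lower number (0.68 log units; beyond the scatter) from compound 1 to compound 3 and a 1.6-fold higher number (0.21 log units; within the scatter) from compound 2 to compound 4, 7.7-fold (0.89 log units) apart, beyond the scatter of two such steps

This shows that the effect of the change depends on the core in this series, but with a single pair on each core it does not show what sets the difference, nor how the change would behave on any further core.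

Still open, on these data alone, is whether a longer chain, or a chain carrying a hydroxyl or an amide, would follow compound 3 or compound 4. Also open, as far as these compounds go, is whether the same picture would hold in a direct receptor binding measurement rather than the whole organism.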